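From a Methylated Benzylamine Back to a Plain Benzylamine

The source may report more compounds than this note shows. Statements on the series, on what has been measured and on what is new or still open speak of the compounds shown alone.

Compound 3 `CN(CCCNS(=O)(=O)c1cc(C(F)(F)F)cc(C(F)(F)F)c1)Cc1ccccc1` gives 46000 nM in a functional assay on Capan-2 cells (Homo sapiens) for inhibition, read by MTT assay, with a stated time of 72 h (a higher number here means a weaker inhibitor of growth, a lower number a stronger inhibitor of growth), the highest number among the three measured compounds; compound 1 `O=S(=O)(NCCCNCc1cccc(Cl)c1)c1cc(C(F)(F)F)cc(C(F)(F)F)c1` gives 8000 nM and compound 2 `O=S(=O)(NCCCNCc1ccc(-c2ccccc2)cc1)c1cc(C(F)(F)F)cc(C(F)(F)F)c1` gives 2200 nM. Compound 4 `O=S(=O)(NCCCNCc1ccc(Br)cc1)c1cc(C(F)(F)F)cc(C(F)(F)F)c1` differs from compound 3 by (4-bromobenzyl)amino in place of benzyl(methyl)amino on a saturated chain carbon, three bonds along the chain from a sulfonamide nitrogen. Within the data shown here, the one measured step that bears on this change runs the opposite way: a 5.8-fold higher number from compound 1 to compound 3 (0.76 log units; beyond the scatter). Since the change in compound 4 largely reverses that step, a step of similar size toward a lower number is expected, about a 6.6-fold lower number from compound 3 to compound 4 (0.82 log units; beyond the scatter). Compound 4 is therefore estimated to give 7000 nM in this assay, with a range from 2500 nM to 20000 nM.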

Compound 4, concentration for 50% growth inhibition: 2000 nM
For compound 4 the middle estimate is 3.5-fold (0.54 log units) above the measured one; the whole stated range lies above it.
By their numbers in this assay, from the lowest: compounds 4 and 2 (each within the scatter of the next); then compound 1; then compound 3.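

Across this assay, (4-bromobenzyl)amino in place of benzyl(methyl)amino gives a 23-fold lower number from compound 3 to compound 4 (1.36 log units; beyond the scatter), a large step. Bromo in place of phenyl gives a 1.1-fold lower number from compound 2 to compound 4 (0.04 log units; within the scatter), within the scatter, whereas 4-bromophenyl in place of 3-chlorophenyl gives a 4.0-fold lower number from compound 1 to compound 4 (0.60 log units; beyond the scatter), so the ring substituent still moves the number in this pair. Nothing available explains these steps. The step to compound 4 joins the loss of the methyl on the amine nitrogen with the gain of bromo, and the compounds shown do not separate them. Going by these compounds, whether a plain benzylamine or a longer chain would hold this level stays open.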